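Trifluoroethyl for dimethylamino on a bile acid receptor amide

The source may report more compounds than this note shows. Statements on the series, on what has been measured and on what is new or still open speak of the compounds shown alone.

Compound 3 `CN(C)c1ccc(C(=O)NCc2ccc(NS(C)(=O)=O)cc2Cl)cc1` is the weakest of the three measured compounds: in an assay on HeLa cells for agonist activity at Bile acid receptor (Homo sapiens), read by a luciferase reporter, with a stated time of 24 h (on this read-out higher numbers stand for an effect only at larger amounts of compound and lower numbers for an effect already at smaller amounts), compound 3 gives 1460 nM, the highest number in the set. Its nearest neighbour is compound 2 `CS(=O)(=O)Nc1ccc(CNC(=O)c2ccc(C34CC(C3)C4)cc2)c(Cl)c1`, which in this assay gives 560 nM, and the furthest is compound 1 `CC(C)(C)c1ccc(C(=O)NCc2ccc(N)cc2Cl)cc1`, which in this assay gives 40 nM. Compound 4 `CS(=O)(=O)Nc1ccc(CNC(=O)c2ccc(CC(F)(F)F)cc2)c(Cl)c1` has not yet been measured; it differs from compound 3 in one place: 2,2,2-trifluoroethyl in place of dimethylamino on an aromatic carbon.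

For the measured compounds named here, only one measured step bears on this change: a 2.6-fold higher number from compound 2 to compound 3 (0.42 log units; beyond the scatter), where a group of five carbon atoms in two four-membered rings gave the lower number and dimethylamino the higher. Going by the values given here, the 2,2,2-trifluoroethyl group entering compound 4 is also five heavy atoms and carries no hydrogen-bond acceptor, so the reverse of that step is the closest guide, though no step compares these two groups directly. Compound 4 is therefore expected to show a modest step toward lower numbers, a 2.4-fold lower number from compound 3 to compound 4 (0.39 log units; beyond the scatter), in this assay. The estimate for compound 4 in this assay is 600 nM, with a range from 200 nM to 1800 nM.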

Compound 4, half-maximal effective concentration: 4000 nM
The estimate for compound 4 lay 6.7-fold (0.82 log units) below the measured number; the whole stated range lies below it.
By their numbers in this assay, from the lowest: compound 1; then compound 2; then compound 3; then compound 4.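

For the compounds shown here, the new step reverses what the one earlier step might have suggested: a 2.7-fold higher number from compound 3 to compound 4 (0.44 log units; beyond the scatter) in this assay, so replacing dimethylamino at this position, para to a large group, does not by itself lower the number. Heavy-atom count alone does not set the result here either, since the groups in compound 2 and compound 4 both count 5 heavy atoms, yet the change between them gives a 7.1-fold higher number from compound 2 to compound 4 (0.85 log units; beyond the scatter), the largest step among the three compounds that differ only at this position. Among these three, the order now runs from the group with two four-membered rings through dimethylamino to 2,2,2-trifluoroethyl, but no measurement at hand accounts for that order.

From the compounds shown here alone, what remains open is whether the higher number of compound 4 goes with the fluorine atoms or with the two-carbon chain, a question that a plain ethyl group or a trifluoromethyl group at this position would help to separate. Also open, going by these compounds, is how far the order of these three groups would hold with the amine of compound 1 in place on the other side of the amide.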